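The compounds below may be only part of what the source reports. "The series", "measured", "known", "first", "only" and "open" are said of these compounds alone.

Compound 1 `O=C(O)CCCC/C=C(\c1cccnc1)c1cccc(Br)c1` is the weaker of the two compounds measured in an assay (Equus caballus) for inhibition of Thromboxane-A synthase (Homo sapiens), using microsomes (a lower number here means a stronger inhibitor, a higher number a weaker inhibitor), where compound 1 gives 180 nM. Compound 2 `COc1ccc(/C(=C/CCCCC(=O)O)c2cccnc2)cc1` gives 80 nM in this assay, a stronger result by a margin beyond the scatter. Compound 3 `C/C(=C/CCCCC(=O)O)c1cccnc1` has not yet been measured; it differs from compound 1 in one place, with methyl in place of 3-bromophenyl on a double-bonded chain carbon bound to an aromatic carbon and a double-bonded chain carbon. Going by the values given here, nothing measured so far shows how this swap affects this assay, so the expected step from compound 1 to compound 3 is a 2.8-fold higher number from compound 1 to compound 3 (0.44 log units; beyond the scatter), toward a weaker inhibitor. Compound 3 is estimated to give 500 nM, within a range from 150 nM to 2000 nM.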

Compound 3, half-maximal inhibitory concentration: 71 nM
Beside the measured number, compound 3's estimate is 7.0-fold (0.85 log units) above it, and the stated range ends above it.
By their numbers in this assay, from the lowest: compounds 3 and 2 (each within the scatter of the next); then compound 1.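

In this assay, the 3-bromophenyl on this double-bonded chain carbon proves not to be needed for inhibition: methyl in its place gives a 2.5-fold lower number from compound 1 to compound 3 (0.40 log units; beyond the scatter). A single carbon therefore does better at this position than a group of seven heavy atoms with an aromatic ring. Nothing available explains this gain. Still open, going by these compounds, is how far this position can be trimmed or changed, for example whether a hydrogen atom or an ethyl group in place of the methyl would keep this level of inhibition.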